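Swapping the aryl on the chain carbon of a sulfonyl enone

The compounds below may be only part of what the source reports. "The series", "measured", "known", "first", "only" and "open" are said of these compounds alone.

Measured compounds:
compound 1, `Cc1ccc(CS(=O)(=O)/C(=C/c2ccc(Br)cc2)C(=O)c2ccc(Cl)cc2)cc1` — 25000 nM
compound 2, `O=C(/C(=C\c1ccc(Cl)cc1)SCc1ccc(Cl)cc1)c1ccc(Br)cc1` — 10000 nM

Two compounds have been run in a functional assay on DU-145 cells (Homo sapiens) for inhibition, read by trypan blue exclusion, with a stated time of 96 h; on this read-out higher numbers stand for weaker inhibition of growth and lower numbers for stronger inhibition of growth. Compound 1 gives 25000 nM, the highest of the two numbers. Its nearest neighbour, compound 2, gives 10000 nM, a lower number by a margin beyond the usual scatter; the two differ in more than one place, so no single step can be read from them.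

Compound 3, `COc1ccccc1/C=C(\C(=O)c1ccc(Cl)cc1)S(=O)(=O)Cc1ccc(C)cc1`, is not yet measured. It differs from compound 1 in one place: 2-methoxyphenyl in place of 4-bromophenyl on a double-bonded chain carbon bound to a double-bonded chain carbon. Among the compounds with values here, nothing among the measured pair speaks to this change, so the step is expected to lie within the scatter, no change at the digits printed from compound 1 to compound 3 (within the scatter), with no clear direction. Compound 3 is therefore expected to give about 25000 nM, between 8000 nM and 70000 nM.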

Compound 3, concentration for 50% growth inhibition: 10000 nM
For compound 3 the middle estimate is 2.5-fold (0.40 log units) above the measured one; the range from low to high includes it.
By their numbers in this assay, from the lowest: compounds 2 and 3 (each within the scatter of the next); then compound 1.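

In this assay, within the data shown here, this position is not silent: 2-methoxyphenyl in place of 4-bromophenyl on a double-bonded chain carbon bound to a double-bonded chain carbon gives a 2.5-fold lower number from compound 1 to compound 3 (0.40 log units; beyond the scatter) and so provides the first single change that can be read. The entering group carries oxygen and one hydrogen-bond acceptor, whereas the leaving group carries bromine and no acceptor, but this one step cannot separate these differences from the change in the ring's substituent and its place. Nothing available explains the lower number.

On these data alone, it remains open whether the step follows from the loss of bromine or the arrival of methoxy, which an unsubstituted phenyl or a 4-methoxyphenyl at this place could help to separate. Also open, as far as these compounds go, is how an aryl bearing an amine or a carboxylic acid would read here.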